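Swapping a thiazole for a pyridine beside the amide nitrogen

This account rests on a few compounds, and the source may have more. Where it says the series, first, only, none or still open, it means among the compounds named here.

Measured so far:
compound 1, `CCN(Cc1ccco1)C(=O)COc1ccc(C)cc1`, 489 nM
compound 2, `CCN(Cc1nccs1)C(=O)COc1ccc(C)cc1`, 3060 nM

Among the measured compounds shown here, in an assay on HEK293 cells for agonist activity at transient receptor potential cation channel subfamily M member 8 (Homo sapiens), read by fluorescence and calcium flux, with a stated time of 15 min (a higher number here means that more compound is needed for the effect, a lower number that less compound is needed), compound 2 gives the higher of the two numbers, with compound 1 giving 489 nM as its only neighbour. For the measured compounds named here, the single measured step, a 6.3-fold higher number from compound 1 to compound 2 (0.80 log units; beyond the scatter), shows that exchanging one small aromatic ring for another at this position can move the number well beyond the scatter. Compound 3, `CCN(Cc1ccccn1)C(=O)COc1ccc(C)cc1`, continues along the same line: pyridin-2-yl in place of 1,3-thiazol-2-yl on a saturated chain carbon bound to an amide-type nitrogen. Going by the values given here, no measured step covers a five-membered to six-membered ring exchange here, so only the size of the one known step offers a guide. The change is expected to land somewhere between the two measured results, an estimated 1.7-fold lower number from compound 2 to compound 3 (0.23 log units; within the scatter) in this assay. Compound 3 is therefore expected to give about 1800 nM, within a range of roughly 500 nM to 6000 nM.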

Compound 3, half-maximal effective concentration: 16000 nM
Estimate against measurement, compound 3: 8.9-fold (0.95 log units) below, outside the stated range (above it).
By their numbers in this assay, from the lowest: compound 1; then compound 2; then compound 3.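

Replacing the five-membered ring with the six-membered pyridin-2-yl in this assay gives a 5.2-fold higher number from compound 2 to compound 3 (0.72 log units; beyond the scatter), so the change does not land between the two earlier results. Set against furan-2-yl, the same ring gives a 33-fold higher number from compound 1 to compound 3 (1.51 log units; beyond the scatter), which shows that the aromatic ring on a saturated chain carbon bound to an amide-type nitrogen can shift the number widely, in the order furan-2-yl, 1,3-thiazol-2-yl, pyridin-2-yl. No measurement at hand accounts for this order.

The compounds shown leave open how a plain phenyl ring or a pyridin-3-yl group would compare at this place. They also leave open whether a group without an aromatic ring, such as a simple amine or a longer carbon chain, would fit this order at all.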